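The source may hold more compounds than are shown below. What is called first, only, known or untested is meant among the compounds shown, and "the series" means these compounds.

Measured compounds in a functional assay on HL-60 cells (Homo sapiens) for antiproliferative activity, read by MTT assay, with a stated time of 48 h; on this read-out higher numbers stand for weaker inhibition and lower numbers for stronger inhibition:

compound 1, `CN(C)CCCn1c(N)c(-c2nc3ccccc3n2C)c2nc(C#N)c(C#N)nc21`: 2120 nM
compound 2, `CCN(CC)CCCn1c(N)c(-c2nc3ccccc3n2C)c2nc(C#N)c(C#N)nc21`: 2810 nM
compound 3, `CN(C)CCCCn1c(N)c(-c2nc3cc(Cl)ccc3[nH]2)c2nc(C#N)c(C#N)nc21`: 1480 nM

Compound 1 and compound 2 share one core and differ only in the amine at the chain end: diethylamino in place of dimethylamino on a saturated chain carbon, three bonds along the chain from an aromatic nitrogen. The step this made in this assay is a 1.3-fold higher number from compound 1 to compound 2 (0.12 log units; within the scatter), so the two values sit together and no order between them can be read.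

Compound 3 carries a different core, and the difference between the two cores is not broken down here. Its value lies close to those of compound 1 and compound 2, all three within the usual scatter of one another.

Compound 4, `CCN(CC)CCCCn1c(N)c(-c2nc3cc(Cl)ccc3[nH]2)c2nc(C#N)c(C#N)nc21`, is not yet measured. It repeats on the core of compound 3 the same kind of change as from compound 1 to compound 2: diethylamino in place of dimethylamino on a saturated chain carbon, four bonds along the chain from an aromatic nitrogen. The place differs in one respect, four bonds along the chain from the aromatic nitrogen instead of three, so the two changes are alike in kind and not identical.

Among the measured compounds shown here, since the one measured instance of this change gave a 1.3-fold higher number from compound 1 to compound 2 (0.12 log units; within the scatter), a step of similar size is expected here, a 1.3-fold higher number from compound 3 to compound 4 (0.11 log units; within the scatter). The expected value for compound 4 in this assay is 1900 nM, estimated to fall between 1000 nM and 3600 nM.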

Compound 4, half-maximal inhibitory concentration: 820 nM
Estimate against measurement, compound 4: 2.3-fold (0.36 log units) above; the whole stated range lies above it.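

In this assay, diethylamino in place of dimethylamino at the chain end gives a 1.8-fold lower number from compound 3 to compound 4 (0.26 log units; within the scatter), and the two instances of this change do not separate: the same change on two cores in this assay, a 1.3-fold higher number (0.12 log units; within the scatter) from compound 1 to compound 2 and a 1.8-fold lower number (0.26 log units; within the scatter) from compound 3 to compound 4, 2.4-fold (0.38 log units) apart, within the scatter of two such steps

On these two pairs, the change can be carried from one core to the other with no step beyond the scatter on either core. Among the compounds shown here, this does not show that the steps on the two cores are the same, nor that the change would stay this small on other cores, since the evidence is only two pairs, and they differ in core and in the place of the change, three bonds along the chain from the aromatic nitrogen in one and four in the other.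

Still open, on these data alone, is whether a larger amine at the chain end, such as dipropylamino, or a longer chain would give a step beyond the scatter. Also open, as far as these compounds go, is what the chain length does alone, with the core and the amine held fixed.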